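A few compounds are considered here, and "the series" means these few. Any claim that something is new, unique, unknown or untested is made for them only; others in the source may bear on it.

Measured in a toxicity assay on Huh-7 cells (Homo sapiens) for cytotoxicity, with a stated time of 3 days; a lower number here means that less compound is tolerated, a higher number that more compound is tolerated:
Compound 1 `C[C@@]1(O)[C@H](O)[C@@H](CO)O[C@H]1n1cc(I)c2c(N)ncnc21`: 19800 nM
Compound 2 `C[C@@]1(O)[C@H](O)[C@@H](CO)O[C@H]1n1cc(-c2cccc3ccccc23)c2c(N)ncnc21`: > 44000 nM

On these data alone, the entry for compound 2 is a limit and not a number, so its exact standing is unknown. It sits at the ceiling of this assay, as the limit of > 44000 nM in this assay, at which 1 of the 2 values shown sits, records, and it is the more tolerated of the two compounds.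

The next compound, compound 3 `C[C@@]1(O)[C@H](O)[C@@H](CO)O[C@H]1n1cc(-c2cccs2)c2c(N)ncnc21`, replaces the naphthalen-1-yl of compound 2 with thiophen-2-yl on the same aromatic carbon: thiophen-2-yl in place of naphthalen-1-yl on an aromatic carbon. For the measured compounds named here, only one measured step bears on this change, and it concerns the same carbon. This is an at least 2.2-fold higher number from compound 1 to compound 2 (0.34 log units; beyond the scatter), in which naphthalen-1-yl took the place of iodo. Going by the values given here, its true size remains open, and no measured compound carries thiophen-2-yl.

Compound 3 keeps an aromatic group there but loses one ring, so it is expected to fall somewhere from the level of compound 1, at 19800 nM, up to the level of compound 2. The expected change is a modest fall in the number, an at least 1.4-fold lower number from compound 2 to compound 3 (0.16 log units; that floor lies within the scatter), though another limit reading would be no surprise. For compound 3 the estimated value is 30000 nM, with an expected range of 12000 nM to 60000 nM.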

Compound 3, half-maximal cytotoxic concentration: 48100 nM
Compound 3: the middle estimate sits 1.6-fold (0.21 log units) below what was measured; the measured number falls inside the stated range.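

In this assay, thiophen-2-yl in place of iodo on the same aromatic carbon, two ring bonds from the ring nitrogen, gives a 2.4-fold higher number from compound 1 to compound 3 (0.39 log units; beyond the scatter). This puts a readable size on a move from iodo to an aromatic group at this position, which the earlier pair could show only as an open-ended step. It also shows that the higher number does not depend on the two six-membered aromatic rings of carbon only in naphthalen-1-yl, since one five-membered aromatic ring with 1 hetero atom also gives it, although the step between compound 2 and compound 3 cannot be read, because the entry for compound 2 is a limit and not a number: the limit of > 44000 nM in this assay, at which 1 of the 3 values shown sits.

The compounds shown therefore leave open whether naphthalen-1-yl or thiophen-2-yl is the better tolerated of the two aromatic groups at this carbon. They also leave open how a group without an aromatic ring, such as an amine or a longer alkyl chain, would read in this assay at this position, and so whether an aromatic ring is needed there at all.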